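Arylamino replaces butoxy on the shared core of compound 2

The source may report more compounds than this note shows. Statements on the series, on what has been measured and on what is new or still open speak of the compounds shown alone.

Measured compounds:
compound 1 `O=C(C1=C(O)C(=O)N(CCCn2ccnc2)C1c1ccc(Br)cc1)c1ccccc1` gives "not active" (no number reported) in a functional assay on U2OS cells (Homo sapiens) for antiproliferative activity, read by MTT assay, with a stated time of 72 h; on this read-out lower numbers stand for stronger inhibition and higher numbers for weaker inhibition
compound 2 `CCCCOC1=C(C(=O)c2ccccc2)C(c2ccc(Br)cc2)N(CCCn2ccnc2)C1=O` gives 32400 nM in this assay
compound 3 `O=C(C1=C(Nc2ccc(OC(F)(F)F)cc2)C(=O)N(CCCn2ccnc2)C1c1ccc(Br)cc1)c1ccccc1` gives 11500 nM in this assay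

Compound 2 stands with the highest of the two numbers reported in this assay; its nearest neighbour is compound 3, and the step of a 2.8-fold lower number from compound 2 to compound 3 (0.45 log units; beyond the scatter) lies beyond the scatter. Compound 1 is reported without a number.

Compound 4 `O=C(C1=C(Nc2cccc(Br)c2)C(=O)N(CCCn2ccnc2)C1c1ccc(Br)cc1)c1ccccc1` has not yet been measured in this assay. It differs from compound 2 as follows: (3-bromophenyl)amino in place of butoxy on a double-bonded ring carbon.

Among the measured compounds shown here, the only measured step that bears on this change is the one from compound 2 to compound 3, where another arylamino group took the place of the same butoxy on the same double-bonded ring carbon, and the number fell modestly, a 2.8-fold lower number from compound 2 to compound 3 (0.45 log units; beyond the scatter). The change to compound 4 is of the same kind, so a step of similar size and in the same direction, a lower number, is expected, and compound 4 is estimated to come out near compound 3.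

Compound 4 is therefore expected to give about 12000 nM in this assay, with a range from 5000 nM to 30000 nM, which means an expected step of a 2.7-fold lower number from compound 2 to compound 4 (0.43 log units; beyond the scatter).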

Compound 4, half-maximal inhibitory concentration: 11900 nM
For compound 4 the middle estimate is 1.0-fold (0.00 log units) above the measured one; the measured number falls inside the stated range.
By their numbers in this assay, from the lowest: compounds 3 and 4 (each within the scatter of the next); then compound 2.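

In this assay the second arylamino group on the double-bonded ring carbon gives a 2.7-fold lower number from compound 2 to compound 4 (0.43 log units; beyond the scatter) and so matches the earlier 2.8-fold lower number from compound 2 to compound 3 (0.45 log units; beyond the scatter) in direction, which means the lower number no longer rests on a single aryl group. The two arylamino compounds also stand level, with a 1.0-fold higher number from compound 3 to compound 4 (0.01 log units; within the scatter) and thus within the scatter, so 3-bromophenyl in place of 4-(trifluoromethoxy)phenyl on the amine nitrogen leaves the number unmoved in this pair. Among the compounds with numbers, both arylamino groups give lower numbers than butoxy, although compound 1 cannot be placed in this order, as it is reported only as "not active" (no number reported) in this assay.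

Compounds 3 and 4 differ in both the substituent on the phenyl ring and its place, so neither can be read alone, and the shown compounds leave open how an unsubstituted phenylamino, a benzylamino or a butylamino group would behave on this carbon. No measurement at hand accounts for the lower numbers of the arylamino compounds compared with compound 2.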